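A few compounds are considered here, and "the series" means these few. Any claim that something is new, unique, unknown or untested is made for them only; others in the source may bear on it.

In an ADME assay on Vero cells (Chlorocebus sabaeus) for cytotoxicity, read by CellTiter-Glo, with a stated time of 72 h (a lower number here means that less compound is tolerated, a higher number that more compound is tolerated), compound 1 (`[O-][n+]1nc(NC2CCCC2)[n+]([O-])c2ccccc21`) gives 10 ug/mL and compound 2 (`[O-][n+]1nc(NC2CCCCC2)[n+]([O-])c2ccccc21`) gives 8.9 ug/mL. Among the compounds with values here, these are the only two numbers so far, and they lie within the scatter of each other, so compound 1 does not stand apart from its neighbour. Within the data shown here, the one measured step is a 1.1-fold lower number from compound 1 to compound 2 (0.05 log units; within the scatter), which swaps cyclopentyl for cyclohexyl on a nitrogen on an aromatic ring.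

Compound 3 (`[O-][n+]1nc(NC2CCCC2)[n+]([O-])c2ccc(Br)cc21`) keeps the cyclopentyl group of compound 1 and changes a different part of the molecule: bromo in place of hydrogen on an aromatic carbon. The bromo group takes the place of hydrogen on an aromatic carbon of a six-membered aromatic ring of carbon only, part of a fused or bridged system of two rings. The step to compound 2 therefore bears on this change only indirectly, since it shows how the numbers behave when another part of the molecule is altered. Among the measured compounds shown here, no measured compound carries a substituent at this place, so the data give no direction for the change. The expected step is a 1.3-fold lower number from compound 1 to compound 3 (0.10 log units; within the scatter), which means no clear shift beyond the scatter is expected. For compound 3, the estimated value in this assay is 8 ug/mL, with an expected range of 3 ug/mL to 20 ug/mL.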

Compound 3, half-maximal cytotoxic concentration: 18 ug/mL
Compound 3: middle estimate off by 2.3-fold (0.35 log units), on the low side, and the stated range covers the measured number.
By their numbers in this assay, from the lowest: compounds 2, 1 and 3 (each within the scatter of the next, the first and the last beyond it).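

In this assay, within the data shown here, the change from hydrogen to bromo on this aromatic carbon gives the first reading for a substituent at this place: (a 1.8-fold higher number from compound 1 to compound 3 (0.26 log units; within the scatter)). Until now, the compounds carried only hydrogen here, so they gave no information about this position, and the cyclopentyl-to-cyclohexyl step concerned a different part of the molecule. The bromo step stays within the usual scatter of repeated measurements, so this single comparison shows no clear shift in how much compound the cells tolerate, and no measurement at hand offers an explanation for the result.

The compounds shown leave open whether other groups on this aromatic carbon, such as chloro, methoxy, an amine or a carboxylic acid, would also stay within the scatter or would move the number clearly in either direction. They also leave open whether bromo would behave the same way on other carbons of this ring, or alongside the cyclohexyl group of compound 2, where a single comparison of the bromo change would need a partner carrying both groups.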